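Swapping 4-bromophenyl for 3-methoxyphenyl on an amide nitrogen

This account rests on a few compounds, and the source may have more. Where it says the series, first, only, none or still open, it means among the compounds named here.

Compound 1 `Cc1cccc(NC(=O)C2(C(=O)Nc3ccc(Nc4ncc5cc(C(=O)N(C)C)n(C6CCCC6)c5n4)cc3)CC2)c1` gives 86.1%
Compound 2 `COc1ccc(NC(=O)C2(C(=O)Nc3ccc(Nc4ncc5cc(C(=O)N(C)C)n(C6CCCC6)c5n4)cc3)CC2)cc1` gives 78.5%
Compound 3 `CN(C)C(=O)c1cc2cnc(Nc3ccc(NC(=O)C4(C(=O)Nc5ccc(Br)cc5)CC4)cc3)nc2n1C1CCCC1` gives 90.3%

All three numbers come from a functional assay on A549 cells (Homo sapiens) for inhibition, read by CCK-8 assay, with a stated time of 72 h, tested at 10 uM; a lower number here means less inhibition of growth, a higher number more inhibition of growth at the concentration tested. Compound 3 carries the highest of the three numbers, yet it cannot be separated from one of its neighbours: the comparison reads a number 4.2 percentage points higher from compound 1 to compound 3 (within the scatter). Only the gap to the other is real: a number 11.8 percentage points higher from compound 2 to compound 3 (beyond the scatter).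

The next molecule is compound 4 `COc1cccc(NC(=O)C2(C(=O)Nc3ccc(Nc4ncc5cc(C(=O)N(C)C)n(C6CCCC6)c5n4)cc3)CC2)c1`, which has 3-methoxyphenyl in place of 4-bromophenyl on an amide-type nitrogen.

For the measured compounds named here, three measured steps change this same aryl group, so they are the only guide. The closest is the one that trades methoxy and bromo, since compound 4 also carries a methoxy group: a number 11.8 percentage points higher from compound 2 to compound 3 (beyond the scatter). Read backwards, it points downward on leaving bromo. The third step stays small: a number 7.6 percentage points lower from compound 1 to compound 2 (within the scatter). Going by the values given here, all the numbers so far lie high in this assay, so a modest drop is expected, of a size near the scatter, and no large collapse. The estimate means an expected a number 8.3 percentage points lower from compound 3 to compound 4 (within the scatter). For compound 4 the expected value is 82%, with an estimated range from 71% to 91%.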

Compound 4, percent growth inhibition at one concentration: 96%
For compound 4 the middle estimate is 14 percentage points below the measured one; the whole stated range lies below it.
By their numbers in this assay, from the lowest: compounds 2, 1, 3 and 4 (each within the scatter of the next, the first and the last beyond it).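

In this assay, the new result shows that the placement of the methoxy group on this aryl ring can matter: with 3-methoxyphenyl in place of 4-methoxyphenyl on the amide-type nitrogen, the comparison reads a number 17.5 percentage points higher from compound 2 to compound 4 (beyond the scatter). The other two comparisons cannot separate the groups, reading a number 9.9 percentage points higher from compound 1 to compound 4 (within the scatter) for methoxy in place of methyl on an aromatic carbon and a number 5.7 percentage points higher from compound 3 to compound 4 (within the scatter) for 3-methoxyphenyl in place of 4-bromophenyl, so this position accepts several different aryl groups with no clear change in the number. Nothing shown here explains the effect of moving the methoxy group.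

Going by these compounds, it remains open whether a 3-bromophenyl group would follow the methoxy pair, and whether an unsubstituted phenyl ring or a phenyl ring carrying an amine or a carboxylic acid would keep the number this high. On these data alone, with compound 4 at 96% at a single concentration, it is also open whether compound 1, compound 3 and compound 4 would differ at lower concentrations.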